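Chloro added to the core of compound 3

The source may hold more compounds than are shown below. What is called first, only, known or untested is meant among the compounds shown, and "the series" means these compounds.

Three compounds of this series have numbers in a functional assay on SNB-75 cells (Homo sapiens) for cytotoxicity, read by sulforhodamine B assay, with a stated time of 48 h; on this read-out higher numbers stand for weaker inhibition of growth and lower numbers for stronger inhibition of growth. Compound 1 `ClCc1ccc(Cn2cnc3nc(Cl)nc(Cl)c32)cc1` gives 3980 nM, compound 2 `ClCc1cccc(Cn2cnc3c(Cl)nc(Cl)nc32)c1` gives 3890 nM, and compound 3 `ClCc1ccccc1Cn1cnc2ncnc(Cl)c21` gives 26900 nM. Compound 3 thus stands highest of the three, beyond the scatter from both compound 1 and compound 2. The next compound, compound 4 `ClCc1ccccc1Cn1cnc2nc(Cl)nc(Cl)c21`, differs from compound 3 by chloro in place of hydrogen on an aromatic carbon. Among the compounds with values here, no measured pair shows this single change, so the size of the step is open; both compounds that carry two chloro groups on the core show lower numbers than compound 3, so a drop beyond the scatter is expected. Compound 4 is estimated at 5000 nM, within 1500 nM to 16000 nM, which would mean an expected step of a 5.4-fold lower number from compound 3 to compound 4 (0.73 log units; beyond the scatter).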

Compound 4, concentration for total growth inhibition: 4460 nM
For compound 4 the middle estimate is 1.1-fold (0.05 log units) above the measured one; the measured number falls inside the stated range.
By their numbers in this assay, from the lowest: compounds 2, 1 and 4 (each within the scatter of the next); then compound 3.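

In this assay, within the data shown here, chloro in place of hydrogen on the aromatic carbon between two ring nitrogen atoms gives a 6.0-fold lower number from compound 3 to compound 4 (0.78 log units; beyond the scatter), the first single-change step. This position on the core is therefore sensitive to substitution, with chloro giving stronger inhibition of growth than hydrogen. Nothing available explains the step.

On these data alone, whether an amine or a methoxy group at this position would also lower the number stays open. Also open, as far as these compounds go, is whether this change gives a similar step when the chloromethyl group sits as in compound 1.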